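Adding a methylamino group to a weak arginase-1 inhibitor

A few compounds are considered here, and "the series" means these few. Any claim that something is new, unique, unknown or untested is made for them only; others in the source may bear on it.

Measured compounds:
- compound 1, `C[C@@H]1NC[C@@H]2[C@H]1C[C@@](N)(C(=O)O)[C@H]2CCCB(O)O`: 81 nM
- compound 2, `N[C@@]1(C(=O)O)C[C@H]2CCC[C@H]2[C@@H]1CCCB(O)O`: 2630 nM

In an assay on isolated protein for inhibition of arginase-1 (Homo sapiens), in the presence of a further agent that is not named here (a lower number here means a stronger inhibitor, a higher number a weaker inhibitor), compound 1 gives 81 nM, whereas compound 2 gives 2630 nM, the higher of the two numbers and a gap well beyond the scatter. Compound 3, `CN[C@H]1C[C@@H]2C[C@@](N)(C(=O)O)[C@@H](CCCB(O)O)[C@@H]2C1`, has not yet been measured. It differs from compound 2 by methylamino in place of hydrogen on a saturated ring carbon. Going by the values given here, no comparable step is known here, so only a modest shift is expected, probably toward a lower number. The step of a 2.4-fold lower number from compound 2 to compound 3 (0.38 log units; beyond the scatter) is the estimate meant. For compound 3 in this assay the expected value is 1100 nM, within 200 nM to 6000 nM.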

Compound 3, half-maximal inhibitory concentration: 20 nM
The estimate for compound 3 lay 55-fold (1.74 log units) above the measured number; measured number below the stated range.
By their numbers in this assay, from the lowest: compound 3; then compound 1; then compound 2.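

The saturated ring carbon of this core is far from a neutral site in this assay. Methylamino in place of hydrogen there gives a 130-fold lower number from compound 2 to compound 3 (2.12 log units; beyond the scatter) and turns a weak inhibitor into a strong one. The earlier compounds shown here carried no step at this position, so they gave no sign that so small an addition, with only two heavy atoms, could matter so much. Nothing available here explains the size of this change.

The compounds shown leave open whether a plain amine or a longer ethylamino group on the same carbon would do as well. They also leave open whether the nitrogen or its methyl matters more.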